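Aryl amides on a shared pyrazole core: compound 3 outlook

The source may hold more compounds than are shown below. What is called first, only, known or untested is meant among the compounds shown, and "the series" means these compounds.

Measured so far:
compound 1, `O=C(Nc1cc(-c2ccccc2)nn1-c1ccccc1)c1cccc(Cl)c1`, 200 nM
compound 2, `O=C(Nc1cc(-c2ccccc2)nn1-c1ccccc1)c1cnccn1`, 400 nM

Both compounds were run in an assay on isolated protein with metabotropic glutamate receptor 5 (Rattus norvegicus) as the target; a higher number here means that more compound is needed for the effect, a lower number that less compound is needed. Within the data shown here, compound 1 gives 200 nM and compound 2 gives 400 nM, so compound 2 holds the highest of the two numbers, with compound 1 as its only neighbour. Among the measured compounds shown here, the single step between them, a 2.0-fold higher number from compound 1 to compound 2 (0.30 log units; within the scatter), is within the scatter, so the two amide groups tried so far are not separated by the data.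

Compound 3, `Cc1cccc(C(=O)Nc2cc(-c3ccccc3)nn2-c2ccccc2)c1`, is still to be measured. Relative to compound 2 the change is 3-methylphenyl in place of pyrazin-2-yl on a carbonyl carbon. For the measured compounds named here, no measured step carries this exact change. The closest comparison is the pair compound 1 and compound 2, where a carbon-only six-membered ring was replaced by a ring with two nitrogen atoms and the number moved only within the scatter. Compound 3 returns to a carbon-only ring, now bearing a methyl group, so the reverse movement is expected: a number near that of compound 1, the step of a 1.6-fold lower number from compound 2 to compound 3 (0.20 log units; within the scatter) expected to stay within the scatter.

Compound 3 is therefore estimated at 250 nM in this assay, with a range from 80 nM to 800 nM.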

Compound 3, half-maximal effective concentration: 100 nM
Compound 3: the middle estimate sits 2.5-fold (0.40 log units) above what was measured; the measured number falls inside the stated range.
By their numbers in this assay, from the lowest: compounds 3, 1 and 2 (each within the scatter of the next, the first and the last beyond it).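

In this assay, among these compounds, 3-methylphenyl in place of pyrazin-2-yl on a carbonyl carbon gives a 4.0-fold lower number from compound 2 to compound 3 (0.60 log units; beyond the scatter) and is the first step to clear the scatter, so the group at this position can separate compounds, although only modestly so far. Methyl in place of chloro on an aromatic carbon gives a 2.0-fold lower number from compound 1 to compound 3 (0.30 log units; within the scatter) and leaves the two substituted phenyl amides unseparated, so only the two ends of the order, compound 2 and compound 3, stand apart. Nothing available here bears on the reason for the step from the pyrazin-2-yl amide to the 3-methylphenyl amide.

The step replaces the ring nitrogens and adds the methyl group in one change, and the compounds shown leave open how much of it belongs to each, a question that the plain phenyl amide would address. Also open, from the compounds shown here alone, is how an amine or a carboxylic acid would read in place of the methyl on that aromatic carbon, and what changes to the shared core, constant in all three compounds, would do to the number.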